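A few compounds are considered here, and "the series" means these few. Any claim that something is new, unique, unknown or untested is made for them only; others in the source may bear on it.

Measured compounds:
Compound 1 `Nc1nc2ccc(I)cc2s1` in a functional assay on the whole organism with Rattus norvegicus as the target (a higher number here means that more compound is needed for the effect, a lower number that less compound is needed), gives > 10 mg/kg, a limit of the assay.
Compound 2 `CC(C)(C)Oc1ccc2nc(N)sc2c1` in this assay gives > 10 mg/kg, also a limit.
Compound 3 `N=c1sc2cc(OC(F)(F)F)ccc2n1CCS(N)(=O)=O` in this assay gives 6 mg/kg.

Among the compounds with values here, compound 3 holds the only number; the other two values sit at the limit of > 10 mg/kg in this assay, at which 2 of the 3 values shown sit. Within the data shown here, the single step between measured compounds, a step that the two limits leave unreadable from compound 1 to compound 2, is unreadable and concerns the aromatic carbon, not the chain on the aromatic nitrogen. Compound 4 `CC[S+]([O-])CCn1c(=N)sc2cc(OC(F)(F)F)ccc21` differs from compound 3 by a group of 4 heavy atoms (2 carbon, 1 oxygen, 1 sulfur; no ring) in place of a group of 4 heavy atoms (1 nitrogen, 2 oxygen, 1 sulfur; no ring), on a saturated chain carbon, two bonds along the chain from an aromatic nitrogen. Among the measured compounds shown here, no measured step bears on this change, so its size and direction remain open. For compound 4 the expected step is a 1.3-fold higher number from compound 3 to compound 4 (0.12 log units; within the scatter), set close to no change and read with a wide margin. Compound 4 is therefore expected to give 8 mg/kg in this assay, with a range from 2 mg/kg to 30 mg/kg.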

Compound 4, dose for half-maximal effect: 1.2 mg/kg
Estimate against measurement, compound 4: 6.7-fold (0.82 log units) above; the whole stated range lies above it.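

Within the data shown here, on the saturated chain carbon, two bonds along the chain from an aromatic nitrogen, replacing sulfamoyl with the group of 2 carbon, 1 oxygen and 1 sulfur gives a 5.0-fold lower number from compound 3 to compound 4 (0.70 log units; beyond the scatter) in this assay; this is the first readable step and the first to bear on this chain. The earlier step cannot be read, as both its values are limits. Nothing shown bears on why this change lowers the number. Still open, on these data alone, is how an amine, a carboxylic acid or a longer chain at this place would read.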